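Taking a chloro away from compound 2

The source may report more compounds than this note shows. Statements on the series, on what has been measured and on what is new or still open speak of the compounds shown alone.

compound 1 `Cc1nc(-c2ccccc2)sc1C(=O)CSc1nc(N)c(C#N)c(-c2ccc(Cl)cc2)n1` gives 10800 nM
compound 2 `Cc1nc(-c2ccc(Cl)cc2)sc1C(=O)CSc1nc(N)c(C#N)c(-c2ccc(Cl)cc2)n1` gives 3420 nM

Within the data shown here, in a functional assay on U-87MG ATCC cells for antiproliferative activity against U-87 MG (Homo sapiens), read by MTT assay, with a stated time of 48 h (on this read-out higher numbers stand for weaker inhibition and lower numbers for stronger inhibition), compound 2 holds the lower of the two numbers so far at 3420 nM while compound 1 reads 10800 nM and so lies above it, beyond the scatter. Compound 3 `Cc1nc(-c2ccc(Cl)cc2)sc1C(=O)CSc1nc(N)c(C#N)c(-c2ccccc2)n1` has not yet been measured. It differs from compound 2 by hydrogen in place of chloro on an aromatic carbon in a single exchange, hydrogen in place of chloro on an aromatic carbon, which turns a 4-chlorophenyl into a phenyl.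

Among the measured compounds shown here, only one measured step bears on this. That step, a 3.2-fold lower number from compound 1 to compound 2 (0.50 log units; beyond the scatter) on chloro in place of hydrogen on an aromatic carbon, was modest. It ran in the opposite sense and at another place in the molecule, so it serves only as a rough guide. A step of similar modest size is therefore expected here, towards a higher number. The estimated change is a 2.2-fold higher number from compound 2 to compound 3 (0.34 log units; beyond the scatter) in this assay and it may prove smaller. Compound 3 is expected at 7500 nM with a range from 2800 nM to 18000 nM as the likely span.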

Compound 3, half-maximal inhibitory concentration: 11400 nM
Compound 3: the middle estimate sits 1.5-fold (0.18 log units) below what was measured; the measured number falls inside the stated range.
By their numbers in this assay, from the lowest: compound 2; then compounds 1 and 3 (each within the scatter of the next).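

Removing the chloro that sits para to a large group on the six-membered aromatic ring of compound 2 costs activity in this assay, with a 3.3-fold higher number from compound 2 to compound 3 (0.52 log units; beyond the scatter), so this 4-chlorophenyl cannot be exchanged for phenyl without a loss beyond the scatter. Among these compounds, until now, only the other 4-chlorophenyl of compound 2 had been tested, through a 3.2-fold lower number from compound 1 to compound 2 (0.50 log units; beyond the scatter); the new step shows that a chloro at each of these two places is tied to a lower number, and that both steps are modest, so compound 2 remains the only compound here with a number clearly lower than those of the others. No measurement offered here explains why this chloro matters.

The compounds shown leave open whether another group at this place, such as bromo, methoxy or an amine, would match the chloro, or whether a halogen is needed there at all. As far as these compounds go, it also remains open whether the two chloro groups act independently, as that would take a comparison with a compound carrying phenyl at both places.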